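A few compounds are considered here, and "the series" means these few. Any claim that something is new, unique, unknown or untested is made for them only; others in the source may bear on it.

Measured compounds:
compound 1 `O=C(N/N=C/c1cccc(Cl)c1)c1ccncc1` gives 300 mg/kg
compound 2 `O=C(N/N=C/c1cccc(Br)c1)c1cccnc1` gives 100 mg/kg

Of the two compounds tested in a functional assay on the whole organism (strain C57B/6) with Mus musculus as the target, in the maximal electroshock model, with a stated time of 0.5 h (on this read-out higher numbers stand for an effect only at larger amounts of compound and lower numbers for an effect already at smaller amounts), compound 2 stands at the lower number with 100 mg/kg, while compound 1 gives 300 mg/kg, a gap that lies beyond the usual scatter. Among the measured compounds shown here, these two differ in more than one place, so their values are simply set side by side and no step is drawn between them.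

Compound 3 `O=C(N/N=C/c1cccc(Cl)c1)c1cccnc1` has not yet been measured. It differs from compound 2 in a single place: chloro in place of bromo on an aromatic carbon, the change sitting on an aromatic carbon of a six-membered aromatic ring of carbon only, meta to a large group. For the measured compounds named here, no pair of measured compounds shows a step of exactly this kind, so nothing measured can be drawn on directly. The expectation for compound 3 therefore rests on the value of compound 2 alone, and a swap of chloro for bromo is expected to move the number little, most likely within the scatter. The expected step is no change at the digits printed from compound 2 to compound 3 (within the scatter). Compound 3 is estimated to give 100 mg/kg in this assay, within a range from 50 mg/kg to 300 mg/kg.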

Compound 3, minimum effective dose: 300 mg/kg
Compound 3: middle estimate off by 3.0-fold (0.48 log units), on the low side, and the stated range covers the measured number.
By their numbers in this assay, from the lowest: compound 2; then compounds 1 and 3 (each within the scatter of the next).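

In this assay, among the compounds shown here, the aromatic carbon meta to a large group turns out to respond to the choice of halogen: chloro in place of bromo gives a 3.0-fold higher number from compound 2 to compound 3 (0.48 log units; beyond the scatter) and is the first single-place change in this set to separate two compounds beyond the scatter. The other single-place comparison reads differently, since pyridin-3-yl in place of pyridin-4-yl on a carbonyl carbon gives no change at the digits printed from compound 1 to compound 3 (within the scatter) and so, with chloro on the ring, this read-out does not tell the two attachments apart. Nothing available bears on the reason for the step between bromo and chloro.

As far as these compounds go, whether the lower number that goes with bromo also holds when the carbonyl carbon carries pyridin-4-yl remains open, and so does whether the two pyridine attachments stay level with bromo on the ring. For the compounds shown here, also open is how this same aromatic carbon would respond to fluoro, iodo, a methoxy group, an amine or a longer chain, so two halogens give only a first reading of the position.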